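Varying the aryl amine: working notes toward compound 3

The source may report more compounds than this note shows. Statements on the series, on what has been measured and on what is new or still open speak of the compounds shown alone.

Measured in a functional assay on A549 cells (Homo sapiens) for antiproliferative activity, read by sulforhodamine B assay, with a stated time of 72 h; on this read-out lower numbers stand for stronger inhibition and higher numbers for weaker inhibition:
- compound 1 `COc1ncc(-c2ccc3ncnc(Nc4ccc(OCCCO)nc4)c3c2)cc1NS(=O)(=O)c1ccc(F)cc1F` gives 9360 nM
- compound 2 `COc1ncc(-c2ccc3ncnc(Nc4cnn(CC(=O)O)c4)c3c2)cc1NS(=O)(=O)c1ccc(F)cc1F` gives 5200 nM

Within the data shown here, compound 2 holds the lower of the two numbers, but the only step measured, a 1.8-fold lower number from compound 1 to compound 2 (0.26 log units; within the scatter), is within the scatter, so the two compounds cannot be ordered. Compound 3 `COc1ncc(-c2ccc3ncnc(Nc4ccc(OCCO)c(Cl)c4)c3c2)cc1NS(=O)(=O)c1ccc(F)cc1F` differs from compound 2 by 3-chloro-4-(2-hydroxyethoxy)phenyl in place of 1-(carboxymethyl)-1H-pyrazol-4-yl on a nitrogen on an aromatic ring. Among the measured compounds shown here, the single step bearing on this exchange was within the scatter, so for compound 3 no change beyond the scatter is expected in this assay, and the expected step is a 1.2-fold higher number from compound 2 to compound 3 (0.06 log units; within the scatter). Compound 3 is estimated at 6000 nM, with a range of 2000 nM to 18000 nM.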

Compound 3, half-maximal inhibitory concentration: 5980 nM
The estimate for compound 3 lay 1.0-fold (0.00 log units) above the measured number; measured number inside the range.
By their numbers in this assay, from the lowest: compounds 2, 3 and 1 (each within the scatter of the next).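

Exchanging 1-(carboxymethyl)-1H-pyrazol-4-yl for 3-chloro-4-(2-hydroxyethoxy)phenyl on a nitrogen on an aromatic ring gives a 1.2-fold higher number from compound 2 to compound 3 (0.06 log units; within the scatter) in this assay, and exchanging 6-(3-hydroxypropoxy)pyridin-3-yl for the same group gives a 1.6-fold lower number from compound 1 to compound 3 (0.19 log units; within the scatter). A chlorine-bearing ring of carbon only therefore joins the two earlier groups at this place, and the three compounds still cannot be ordered. Nothing available explains this result.

As far as these compounds go, whether an amine or a longer chain in place of the 2-hydroxyethoxy group would give a step beyond the scatter stays open. The separate contributions of the chlorine and the 2-hydroxyethoxy group also remain unresolved.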